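A few compounds are considered here, and "the series" means these few. Any claim that something is new, unique, unknown or untested is made for them only; others in the source may bear on it.

Measured compounds:
compound 1, `CN(C)c1ccc(Nc2nccc(-c3ccsc3)n2)cc1`, gives 2100 nM in a functional assay for inhibition, with Homo sapiens as the target; on this read-out lower numbers stand for stronger inhibition and higher numbers for weaker inhibition;
compound 2, `Cc1ccsc1-c1ccnc(Nc2ccc(N(C)C)cc2)n1`, gives 1800 nM in this assay;
compound 3, `COc1cccc(Nc2nccc(-c3ccsc3)n2)c1`, gives 1800 nM in this assay.

All three numbers sit close together, and no one of them can be called stronger or weaker than the others. Compound 1 and compound 2 differ in one place, (3-methylthiophen-2-yl in place of thiophen-3-yl on an aromatic carbon), and this change made a step of a 1.2-fold lower number from compound 1 to compound 2 (0.07 log units; within the scatter), which lies within the scatter. Compound 3 carries a different core from compound 1; the difference between the two cores is not broken down here.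

Compound 4, `COc1cccc(Nc2nccc(-c3sccc3C)n2)c1`, has not yet been measured. It differs from compound 3 by 3-methylthiophen-2-yl in place of thiophen-3-yl on an aromatic carbon. Around the place of the change, the group it is meta to is given for compound 3 as a group of 9 heavy atoms and for compound 1 as a large group, so the two changes are of the same kind rather than the same.

Because the earlier change gave a 1.2-fold lower number from compound 1 to compound 2 (0.07 log units; within the scatter), compound 4 is expected to show a step of a 1.2-fold lower number from compound 3 to compound 4 (0.08 log units; within the scatter) in this assay. Compound 4 is estimated at 1500 nM, expected between 700 nM and 3200 nM.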

Compound 4, half-maximal inhibitory concentration: > 24000 nM
Compound 4 was reported as a limit; the forecaster's own chance of this, stated with the estimate: 3%; at least 16-fold (1.20 log units) between middle value and limit.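

In this assay, putting 3-methylthiophen-2-yl in place of thiophen-3-yl gave an at least 13-fold higher number from compound 3 to compound 4 (1.12 log units; beyond the scatter), so the change did not carry over from one core to the other in the same way: the same change on two cores in this assay, a 1.2-fold lower number (0.07 log units; within the scatter) from compound 1 to compound 2 and an at least 13-fold higher number (1.12 log units; beyond the scatter) from compound 3 to compound 4, at least 15-fold (1.19 log units) apart, beyond the scatter of two such steps

Compound 4 gives > 24000 nM, which is a limit of the assay and not a number, so the step shows a lower bound on the gap rather than its full size.

These two pairs show only that the outcome of this change differed between these two cores; they do not show which feature of the cores lies behind the difference, or what the change would do on a third core.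

The compounds shown leave open whether thiophen-2-yl, which lacks the methyl, would behave on these cores as 3-methylthiophen-2-yl does. They also leave open whether a phenyl in that place would give a number like that of compound 3 or a limit like that of compound 4.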